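Step to the 3,5-difluorophenyl analogue in the Vero cytotoxicity series

The compounds below may be only part of what the source reports. "The series", "measured", "known", "first", "only" and "open" are said of these compounds alone.

Compound 1 `CCOC(=O)c1cc(-c2cccc(OCc3cccc([N+](=O)[O-])c3)c2)on1` carries a 3-nitrophenyl on the chain that links the shared core to the aromatic ether. In an ADME assay on Vero cells (Chlorocebus sabaeus) for cytotoxicity, with a stated time of 72 h (a lower number here means a stronger inhibitor, a higher number a weaker inhibitor), compound 1 gives > 128000 nM, which is a limit of the assay and not a number. Compound 2 `CCOC(=O)c1cc(-c2cccc(OCc3ccc(C(F)(F)F)cc3)c2)on1` in this assay likewise gives > 128000 nM, a limit. Compound 3 `CCOC(=O)c1ccc(COc2cccc(-c3cc(C(=O)OCC)no3)c2)cc1` in this assay also gives > 128000 nM, again a limit. For the measured compounds named here, the only single-point step among the measured compounds, a step that the two limits leave unreadable from compound 2 to compound 3, therefore cannot be read, and the series shows only (the limit of > 128000 nM in this assay, at which 3 of the 3 values shown sit).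

Compound 4 `CCOC(=O)c1cc(-c2cccc(OCc3cc(F)cc(F)c3)c2)on1` differs from compound 1 by 3,5-difluorophenyl in place of 3-nitrophenyl on a saturated chain carbon bound to an oxygen on an aromatic ring. Going by the values given here, no measured step bears on this change, since every value so far is a limit. Compound 4 is expected to remain at or beyond that limit, with an estimated step that the limit leaves unreadable from compound 1 to compound 4. For compound 4 in this assay the estimate is 200000 nM, expected to lie between 100000 nM and 500000 nM.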

Compound 4, half-maximal inhibitory concentration: > 128000 nM
Compound 4: only a limit was reported; the forecaster's own chance of this, stated with the estimate: 85%; the middle value does not contradict the limit.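

Compound 1 and compound 4 both stand at a limit of the assay and not at a number, so no new step can be read between them in this assay: the limit of > 128000 nM in this assay, at which 4 of the 4 values shown sit.

The compounds shown leave open how far any of them lies from that limit, and whether any change on the aromatic ether would give a readable value in this assay.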